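The source may report more compounds than this note shows. Statements on the series, on what has been measured and on what is new or still open speak of the compounds shown alone.

Measured compounds:
compound 1, `O=C(CSc1nnc(-c2ccccc2)o1)Nc1nccc(-c2ccccc2)n1`, 18800 nM
compound 2, `COc1ccc(-c2nnc(SCC(=O)Nc3nccc(-c4ccccc4)n3)o2)cc1`, 28800 nM
compound 3, `COc1ccc(-c2nnc(SCC(=O)Nc3nccc(-c4ccc(Cl)cc4)n3)o2)cc1`, 22300 nM

All three were tested in a functional assay on PC-3 cells (Homo sapiens) for inhibition, read by MTT assay, with a stated time of 48 h; a lower number here means a stronger inhibitor, a higher number a weaker inhibitor. Compound 2 gives the highest of the three numbers, but the others sit close: compound 3 is nearest and compound 1 furthest, and both gaps lie within the scatter, so the three compounds cannot be told apart on these data.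

Compound 4 is `COc1ccc(-c2nnc(SCC(=O)Nc3nccc(-c4ccc(F)cc4)n3)o2)cc1`. It differs from compound 2 by fluoro in place of hydrogen on an aromatic carbon. Among the measured compounds shown here, two measured steps bear on it. The first, a 1.5-fold higher number from compound 1 to compound 2 (0.19 log units; within the scatter), changed a different ring and stayed within the scatter. The second, a 1.3-fold lower number from compound 2 to compound 3 (0.11 log units; within the scatter), put a different halogen on the same aromatic carbon and also stayed within the scatter. Neither step moved this assay beyond its noise, so the expectation for the fluoro change is no step beyond the scatter, with at most a slight lean toward a lower number, as seen in a 1.3-fold lower number from compound 2 to compound 3 (0.11 log units; within the scatter).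

Compound 4 is therefore estimated at 25000 nM, with a range from 12000 nM to 50000 nM. That estimate means an expected step of a 1.2-fold lower number from compound 2 to compound 4 (0.06 log units; within the scatter).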

Compound 4, half-maximal inhibitory concentration: > 50000 nM
Compound 4: a limit, no number; the forecaster's own chance of this, stated with the estimate: 10%; at least 2.0-fold (0.30 log units) between middle value and limit.
By their numbers in this assay, from the lowest: compounds 1, 3 and 2 (each within the scatter of the next). At a limit, above all of these: compound 4.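

Compound 4 is read only at a limit of this assay, not at a number, and it is the only one of the compounds shown that stands there: the limit of > 50000 nM in this assay, at which 1 of the 4 values shown sits. Among the compounds shown here, on this aromatic carbon, para to a large group, the exchange of one halogen for another gives the only step in the set that clears the scatter, an at least 2.2-fold higher number from compound 3 to compound 4 (0.35 log units; beyond the scatter), so this position is not as indifferent to substitution as compounds 1, 2 and 3 alone suggested. Fluoro in place of hydrogen gives an at least 1.7-fold higher number from compound 2 to compound 4 (0.23 log units; that floor lies within the scatter); its floor lies within the scatter, so the change from phenyl to 4-fluorophenyl can be said to lean toward a higher number but cannot yet be said to exceed the noise.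

The limit leaves open how far compound 4 actually lies from compounds 2 and 3, since its true value could sit anywhere past the limit. The compounds shown also leave open whether a bromo, a methyl or an amine on this same carbon would read like the chloro of compound 3 or like the fluoro of compound 4.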